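A few compounds are considered here, and "the series" means these few. Any claim that something is new, unique, unknown or untested is made for them only; others in the source may bear on it.

Of the compounds shown here, two built on a shared core have been measured in an assay on cells for antagonist activity at transient receptor potential cation channel subfamily V member 1 (Homo sapiens), read by FLIPR and calcium flux, with a stated time of 15 min; a higher number here means a weaker inhibitor, a lower number a stronger inhibitor. Compound 1 `Cc1cc(C(C)C(=O)NCc2ccc(C(F)(F)F)nc2N2CCC(C)CC2)ccc1NS(C)(=O)=O` gives 0.6 nM in this assay. Compound 2 `CC1CCN(c2nc(C(F)(F)F)ccc2CNC(=O)C(C)c2ccc(NS(N)(=O)=O)c(F)c2)CC1` gives 2.7 nM in this assay, the higher of the two numbers; the gap to compound 1 lies beyond the usual scatter of repeated measurements, so compound 2 is the weaker inhibitor of the pair. Compound 3 `CCN(c1ccc(C(C)C(=O)NCc2ccc(C(F)(F)F)nc2N2CCC(C)CC2)cc1F)S(C)(=O)=O` differs from compound 2 at a single site: ethyl(methylsulfonyl)amino in place of sulfamoylamino on an aromatic carbon. For the measured compounds named here, no two measured compounds differ at only one site, so no measured step can be taken as a guide for this change. Compound 3 is expected to show a higher number than compound 2, a step beyond the scatter, estimated as a 5.6-fold higher number from compound 2 to compound 3 (0.74 log units; beyond the scatter). For compound 3 the expected value in this assay is 15 nM, with a range from 2 nM to 100 nM.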

Compound 3, inhibition constant: 22.7 nM
Compound 3: middle estimate off by 1.5-fold (0.18 log units), on the low side; low and high end bracket the measured number.
By their numbers in this assay, from the lowest: compound 1; then compound 2; then compound 3.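

For the compounds shown here, the step gives the first reading of a change at this aromatic carbon, ortho to a fluoro group and para to a large group. In this assay, ethyl(methylsulfonyl)amino in place of sulfamoylamino brings an 8.4-fold higher number from compound 2 to compound 3 (0.92 log units; beyond the scatter) on the shared core, so this position does not accept the exchange without a measurable loss. The exchange replaces a group with 2 hydrogen-bond donors by one with 0 hydrogen-bond donors, but nothing available explains the loss, and no supporting measurement bears on it.

The compounds shown leave open whether the loss follows from the ethyl on the nitrogen or from the methyl on the sulfur, which a plain methylsulfonylamino group at this position would help to separate. They also leave open how a methyl or a propyl on that nitrogen would read.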